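A few compounds are considered here, and "the series" means these few. Any claim that something is new, unique, unknown or untested is made for them only; others in the source may bear on it.

Measured so far in a functional assay on HeLa cells (Homo sapiens) for cytotoxicity, read by MTT assay; on this read-out lower numbers stand for stronger inhibition and higher numbers for weaker inhibition: compound 2 `CCC(C)(O)CC(=O)O[C@H](CC=C(C)C)C1=CC(=O)c2c(O)ccc(O)c2C1=O` gives 25200 nM; compound 1 `CCCCC(O)CC(=O)O[C@H](CC=C(C)C)C1=CC(=O)c2c(O)ccc(O)c2C1=O` gives 72200 nM; compound 3 `CC(C)=CC[C@@H](OC(=O)c1ccco1)C1=CC(=O)c2c(O)ccc(O)c2C1=O` gives 80300 nM.

Compound 2 has the lowest number of the three, set apart from compound 1 by a 2.9-fold lower number from compound 1 to compound 2 (0.46 log units; beyond the scatter) and from compound 3 by a 3.2-fold higher number from compound 2 to compound 3 (0.50 log units; beyond the scatter). Compound 4 `CCC(O)CO[C@H](CC=C(C)C)C1=CC(=O)c2c(O)ccc(O)c2C1=O` takes the step (2-hydroxybutyl in place of (2-hydroxy-2-methylbutyl)carbonyl on an oxygen on a saturated carbon). Among the measured compounds shown here, no measured step exchanges the (2-hydroxy-2-methylbutyl)carbonyl for a group bound directly through the oxygen, so the bearing of the measured steps is indirect: both show that altering what hangs from that oxygen shifts this assay only modestly. A modest rise toward the numbers of compound 1 and compound 3 is therefore expected, a 2.0-fold higher number from compound 2 to compound 4 (0.30 log units; within the scatter). Compound 4 is estimated at 50000 nM, range 20000 nM to 125000 nM.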

Compound 4, half-maximal inhibitory concentration: 28700 nM
Estimate against measurement, compound 4: 1.7-fold (0.24 log units) above; the range from low to high includes it.
By their numbers in this assay, from the lowest: compounds 2 and 4 (each within the scatter of the next); then compounds 1 and 3 (each within the scatter of the next).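

In this assay, exchanging (2-hydroxy-2-methylbutyl)carbonyl for 2-hydroxybutyl on this oxygen gives a 1.1-fold higher number from compound 2 to compound 4 (0.06 log units; within the scatter), so in this pair a group without the carbonyl matches the lowest number seen earlier. The same group gives a 2.8-fold lower number from compound 3 to compound 4 (0.45 log units; beyond the scatter) and a 2.5-fold lower number from compound 1 to compound 4 (0.40 log units; beyond the scatter), placing 2-hydroxybutyl with compound 2 and apart from the furan-2-yl and 2-hydroxyhexyl esters. No supporting data explain these steps. Going by these compounds, whether the hydroxyl of 2-hydroxybutyl contributes remains open, as does the effect of an amine or a carboxylic acid on a longer chain at this oxygen.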